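Nitro to Cyano on the Benzyl Group of Compound 1

The source may hold more compounds than are shown below. What is called first, only, known or untested is meant among the compounds shown, and "the series" means these compounds.

Measured so far:
Compound 1 `Nc1nc(O)c2c(n1)n(C1OC(CO)[C@@H](O)[C@H]1O)c(=O)n2Cc1ccc([N+](=O)[O-])cc1` gives 40 uM in a functional assay (B cells) with Mus musculus as the target; on this read-out higher numbers stand for an effect only at larger amounts of compound and lower numbers for an effect already at smaller amounts.
Compound 2 `C=CCSc1nc2c(O)nc(N)nc2n1C1OC(CO)[C@@H](O)[C@H]1O` gives 107 uM in this assay.
Compound 3 `C=CCn1c(=S)n(C2OC(COC(C)=O)[C@H]3OC(C)(C)O[C@@H]23)c2nc(N)nc(O)c21` gives 50 uM in this assay.

Of the compounds shown here, three built on the shared core have been measured. Compound 1 shows the lowest number of the three. Its nearest neighbour is compound 3, whose number is higher by an amount that stays within the usual scatter of repeated measurements, so the two cannot be ranked against each other. The furthest is compound 2, whose number lies higher by a margin beyond that scatter.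

The next compound, compound 4 `N#Cc1ccc(Cn2c(=O)n(C3OC(CO)[C@@H](O)[C@H]3O)c3nc(N)nc(O)c32)cc1`, has not yet been measured in this assay. It differs from compound 1 in one place only: cyano in place of nitro on an aromatic carbon. The group sits on an aromatic carbon of a six-membered aromatic ring of carbon only.

For the measured compounds named here, no pair of measured compounds shows a step of exactly this kind, so the size of the change in this assay is open. From compound 1 to compound 4 a step of a 1.1-fold higher number from compound 1 to compound 4 (0.05 log units; within the scatter) is expected, that is, no change beyond the scatter. Compound 4 is therefore estimated at 45 uM, with a range from 15 uM to 135 uM.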

Compound 4, concentration for half-maximal effect: 15 uM
Compound 4: middle estimate off by 3.0-fold (0.48 log units), on the high side; the range from low to high includes it.
By their numbers in this assay, from the lowest: compound 4; then compounds 1 and 3 (each within the scatter of the next); then compound 2.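

In this assay, for the compounds shown here, this is the first change that can be read in one place, because compounds 1, 2 and 3 differ from each other in more than one place and none of them isolates the benzyl group. Exchanging 4-nitrobenzyl for 4-cyanobenzyl gives a 2.7-fold lower number from compound 1 to compound 4 (0.43 log units; beyond the scatter) and shows that the aromatic carbon para to a large group is not indifferent to what it carries, although the step is modest and rests on this single pair. The group that enters has fewer heavy atoms and fewer hydrogen-bond acceptors than the one that leaves, and it is compatible with a lower number, but no measurement shown here explains the step.

What the compounds shown leave open is whether other groups on this carbon, such as an amine, a carboxylic acid or a methoxy group, would move the number further down or back up. From the compounds shown here alone, it also remains open whether a cyano group at another place on the ring, or the same exchange on a compound with a different sugar portion, would give a step of similar size.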